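The compounds below may be only part of what the source reports. "The series", "measured", "known", "first", "only" and "open" are said of these compounds alone.

Compound 3 `Nc1ccc(C(=O)/C=C/c2ccccc2)cc1` carries a free amino group on one ring and no substituent on the other. In a functional assay on FM3A cells (Mus musculus) for antiproliferative activity, with a stated time of 48 h (on this read-out lower numbers stand for stronger inhibition and higher numbers for weaker inhibition), compound 3 gives 34000 nM, the highest of the three measured numbers. Compound 1 `C=C(Br)C(=O)Nc1ccc(C(=O)/C=C/c2cc(OC)cc(OC)c2)cc1` and compound 2 `C=C(Br)C(=O)Nc1ccc(C(=O)/C=C/c2cc(OC)c(OC)c(OC)c2)cc1` rest on a different core, and the difference between that core and the core of compound 3 is not broken down here. In this assay compound 1 gives 2000 nM and compound 2 gives 1800 nM. Compounds 1 and 2 differ in one place, (methoxy in place of hydrogen on an aromatic carbon), and that step is a 1.1-fold lower number from compound 1 to compound 2 (0.05 log units; within the scatter).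

Compound 4 `COc1cccc(/C=C/C(=O)c2ccc(N)cc2)c1` has not yet been measured. It differs from compound 3 by methoxy in place of hydrogen on an aromatic carbon. For the measured compounds named here, this is the same kind of change as the one from compound 1 to compound 2, but not the same: in compound 2 the entering methoxy sits ortho to two methoxy groups and para to a large group, whereas in compound 4 it sits meta to a large group on a ring that otherwise bears nothing. Going by the values given here, with only one measured step of this kind to lean on, the expected step in this assay is a 1.5-fold lower number from compound 3 to compound 4 (0.19 log units; within the scatter), and that expectation rests on the fact that a 1.1-fold lower number from compound 1 to compound 2 (0.05 log units; within the scatter) lies within the scatter. Compound 4 is accordingly estimated at 22000 nM in this assay, with a likely range from 7000 nM to 60000 nM.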

Compound 4, half-maximal inhibitory concentration: 45000 nM
Compound 4: middle estimate off by 2.0-fold (0.31 log units), on the low side; low and high end bracket the measured number.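

In this assay, methoxy in place of hydrogen on an aromatic carbon, meta to a large group, gives a 1.3-fold higher number from compound 3 to compound 4 (0.12 log units; within the scatter), so on the core of compound 3 the step stays within the scatter. Set beside the earlier step, the same kind of change reads alike on the two cores, with no difference that can be told apart: the same change on two cores in this assay, a 1.1-fold lower number (0.05 log units; within the scatter) from compound 1 to compound 2 and a 1.3-fold higher number (0.12 log units; within the scatter) from compound 3 to compound 4, 1.5-fold (0.17 log units) apart, within the scatter of two such steps. This shows that, for these two pairs, adding a methoxy leaves no readable mark on the antiproliferative read-out, but it does not establish a rule for other cores, nor does it show that the change is without effect in general, as it rests on two steps only, on rings that carry different groups.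

The compounds shown leave open whether a different group at the same place, such as a hydroxyl, a fluorine or a longer alkoxy chain, would give a step beyond the scatter on the core of compound 3. They also leave open how a methoxy at another carbon of that ring would read, and whether an acetamide in place of the free amino group of compound 3 would alter the number.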